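A few compounds are considered here, and "the series" means these few. Any claim that something is new, unique, unknown or untested is made for them only; others in the source may bear on it.

In a functional assay on MCF7 cells (Homo sapiens) for cytotoxicity, read by MTT assay, with a stated time of 72 h (a lower number here means a stronger inhibitor, a higher number a weaker inhibitor), compound 1 (`COc1cc2ncnc(Nc3ccc(F)c(Cl)c3)c2cc1NC(=O)N/N=C/c1ccc(F)cc1`) gives 35100 nM and compound 2 (`COc1cc2ncnc(Nc3ccc(F)c(Cl)c3)c2cc1NC(=O)N/N=C/c1ccc([N+](=O)[O-])cc1`) gives 36800 nM, which is a 1.0-fold higher number from compound 1 to compound 2 (0.02 log units; within the scatter). Compound 3 (`COc1ccc(/C=N/NC(=O)Nc2cc3c(Nc4ccc(F)c(Cl)c4)ncnc3cc2OC)cc1`) has the lowest number of the three, at 8140 nM. Compound 4 (`COc1cc2ncnc(Nc3ccc(F)c(Cl)c3)c2cc1NC(=O)N/N=C/c1ccc(OC)c(OC)c1OC`) keeps the rest of compound 3 and carries 2,3,4-trimethoxyphenyl in place of 4-methoxyphenyl on a carbon with a double bond to nitrogen.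

Within the data shown here, two measured steps bear on this change, since both arrive at the 4-methoxyphenyl group of compound 3. They are a 4.3-fold lower number from compound 1 to compound 3 (0.63 log units; beyond the scatter) and a 4.5-fold lower number from compound 2 to compound 3 (0.66 log units; beyond the scatter), both modest. Neither step adds further methoxy groups, so the data do not show whether more of them would lower the number again or raise it. No clear move in either direction can be expected, so the expected change stays inside the scatter, at an estimated 1.2-fold higher number from compound 3 to compound 4 (0.09 log units; within the scatter). For compound 4 the estimated value is 10000 nM, with an expected range from 3500 nM to 30000 nM.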

Compound 4, half-maximal inhibitory concentration: "not active" (no number reported)
No number was reported for compound 4, and the estimate cannot be compared.
By their numbers in this assay, from the lowest: compound 3; then compounds 1 and 2 (each within the scatter of the next).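

Among these compounds, compound 4 is reported as "not active" without a number, so no step from compound 3 to compound 4 can be read. The compounds shown leave open how the 2,3,4-trimethoxyphenyl group compares in size of effect with 4-methoxyphenyl. Nothing shown accounts for this result.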